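A few compounds are considered here, and "the series" means these few. Any claim that something is new, unique, unknown or untested is made for them only; others in the source may bear on it.

Compound 2 `COCNc1n[n+]([O-])c2ccccc2[n+]1[O-]` is measured in a functional assay on K562 cells (Homo sapiens) for cytotoxicity, read by MTT assay, with a stated time of 72 h (on this read-out lower numbers stand for stronger inhibition and higher numbers for weaker inhibition), where compound 2 gives 3790 nM. Of the three compounds measured, compound 2 stands second highest. Its nearest neighbour is compound 3 `[O-][n+]1nc(NCOCc2ccccc2)[n+]([O-])c2ccccc21`, which in this assay gives 4690 nM; the furthest is compound 1 `COc1ccc2c(c1)[n+]([O-])nc(NCOC(C)c1ccccc1)[n+]2[O-]`, which in this assay gives 250 nM, a compound that differs from compound 2 in more than one place, so its value is noted only as it stands.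

The step now followed leads from compound 2 to compound 4 `COc1ccc(COCNc2n[n+]([O-])c3ccccc3[n+]2[O-])cc1`, with the change (4-methoxyphenyl in place of hydrogen on a saturated chain carbon bound to an oxygen on a saturated carbon). Among the compounds with values here, the one measured step that bears on it is the step from compound 2 to compound 3, where a phenyl group took the place of hydrogen at the same position and gave a 1.2-fold higher number from compound 2 to compound 3 (0.09 log units; within the scatter). That step stayed within the scatter, and the present change adds only a methoxy group to such a phenyl. On this basis compound 4 is expected to give, in this assay, a number close to that of compound 2, with a step of about a 1.1-fold higher number from compound 2 to compound 4 (0.02 log units; within the scatter) and no change beyond the scatter. The estimate for compound 4 is 4000 nM, in a range from 1500 nM to 10000 nM.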

Compound 4, half-maximal inhibitory concentration: 660 nM
Beside the measured number, compound 4's estimate is 6.1-fold (0.78 log units) above it, and the stated range ends above it.
By their numbers in this assay, from the lowest: compound 1; then compound 4; then compounds 2 and 3 (each within the scatter of the next).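

In this assay the position on the saturated chain carbon bound to an oxygen on a saturated carbon proves sensitive to what is placed there: 4-methoxyphenyl in place of hydrogen gives a 5.7-fold lower number from compound 2 to compound 4 (0.76 log units; beyond the scatter) and so lies beyond the scatter, whereas phenyl at the same place gave a 1.2-fold higher number from compound 2 to compound 3 (0.09 log units; within the scatter) and stayed within it. The direct comparison of the two aryl groups, methoxy in place of hydrogen on an aromatic carbon, gives a 7.1-fold lower number from compound 3 to compound 4 (0.85 log units; beyond the scatter) and shows that among these compounds the lower number appears only with the methoxy group present, not with the added phenyl ring alone. No measurement shown here accounts for this difference between the two groups.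

From the compounds shown here alone, it remains open whether a hydroxy group, a chlorine atom or a dimethylamino group on that aromatic carbon would give a step of similar size to that of methoxy. Also open, going by these compounds, is whether a longer chain or a pyridine ring in place of the 4-methoxyphenyl would keep the number of compound 4 in this range.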